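The source may report more compounds than this note shows. Statements on the series, on what has been measured and on what is new or still open speak of the compounds shown alone.

Compound 3 `COc1ccc(-c2cn3ccnc3c(-c3ccc4ncn(C5CCCCC5)c4c3)n2)cc1` stands lowest of the three compounds measured in a functional assay on SF-539 cells (Homo sapiens) for inhibition, read by sulforhodamine B assay, with a stated time of 48 h, tested at 10 uM; a lower number here means less inhibition, a higher number more inhibition at the concentration tested (going by the name of the read-out): compound 3 gives -43.4%, while compound 1 `Brc1cn2ccnc2c(-c2ccc3ncn(C4CCCCC4)c3c2)n1` gives 10% and compound 2 `c1ccc(-c2cn3ccnc3c(-c3ccc4ncn(C5CCCCC5)c4c3)n2)cc1` gives 27.8%. Compound 4 `O=Cc1ccc(-c2cn3ccnc3c(-c3ccc4ncn(C5CCCCC5)c4c3)n2)cc1` differs from compound 3 by formyl in place of methoxy on an aromatic carbon. Within the data shown here, no measured step exchanges these two groups, so only the steps that changed the group at this position bear on it: a number 17.8 percentage points higher from compound 1 to compound 2 (beyond the scatter), a number 53.4 percentage points lower from compound 1 to compound 3 (beyond the scatter) and a number 71.2 percentage points lower from compound 2 to compound 3 (beyond the scatter), which show that one change of group there can move the inhibition a long way in either direction. The step of a number 48.4 percentage points higher from compound 3 to compound 4 (beyond the scatter) is expected, though with little confidence. Compound 4 is therefore estimated to give 5%, within a range from -40% to 40%.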

Compound 4, a percentage reported as inhibition, at one concentration (the size of the read-out at that concentration, not a potency): 31.5%
Estimate against measurement, compound 4: 26.5 percentage points below, within the range that was stated.
By their numbers in this assay, from the lowest: compound 3; then compound 1; then compounds 2 and 4 (each within the scatter of the next).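

Methoxy and formyl carry the same count of heavy atoms, yet in this assay exchanging them gives a number 74.9 percentage points higher from compound 3 to compound 4 (beyond the scatter), so at this place the outcome depends on which group sits there, not just on its size in atoms. Formyl in place of hydrogen gives a number 3.7 percentage points higher from compound 2 to compound 4 (within the scatter), so of these two groups only methoxy separates from the plain phenyl. Relative to bromo, 4-formylphenyl gives a number 21.5 percentage points higher from compound 1 to compound 4 (beyond the scatter).

Nothing available explains the gap between methoxy and formyl. Going by these compounds, whether an amine, a carboxylic acid or a longer chain at this place would track methoxy or formyl stays open.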